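Chloro in place of hydrogen on compound 1

A few compounds are considered here, and "the series" means these few. Any claim that something is new, unique, unknown or untested is made for them only; others in the source may bear on it.

Measured in a functional assay on TSGH 8302 cells (Homo sapiens) for cytotoxicity; on this read-out higher numbers stand for weaker inhibition and lower numbers for stronger inhibition:
Compound 1 `Cc1ccc(S(=O)(=O)N/C(=N\O)Nc2ccc(Cl)cc2)cc1`: 46 ug/mL
Compound 2 `N#Cc1c(Cl)cccc1Oc1ccc(S(=O)(=O)N/C(=N\O)Nc2ccc(Cl)cc2)cc1`: 168 ug/mL
Compound 3 `CCCCOc1ccc(S(=O)(=O)N/C(=N\O)Nc2ccc(Cl)cc2)cc1`: 37 ug/mL

Compound 1 stands second highest of these three numbers, though only nominally. One neighbour is close, with a 1.2-fold lower number from compound 1 to compound 3 (0.09 log units; within the scatter). The other is clearly separated, with a 3.7-fold higher number from compound 1 to compound 2 (0.56 log units; beyond the scatter). The remaining step, a 4.5-fold lower number from compound 2 to compound 3 (0.66 log units; beyond the scatter), is also modest.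

Compound 4 `Cc1ccc(S(=O)(=O)N/C(=N\O)Nc2ccc(Cl)c(Cl)c2)cc1` has not yet been measured. It keeps the core of compound 1 and differs in one place: chloro in place of hydrogen on an aromatic carbon. This is chloro in place of hydrogen on an aromatic carbon, ortho to a chloro group and meta to a large group.

Among the measured compounds shown here, no measured step touches this place. Each one exchanges the methyl of compound 1, or the group standing in its stead, so the three steps bear on the change only indirectly. They do show that even the exchange to 3-chloro-2-cyanophenoxy gave only a modest step, a 3.7-fold higher number from compound 1 to compound 2 (0.56 log units; beyond the scatter), while the exchange to butoxy stayed within the scatter.

For a single chloro, no step beyond the scatter is therefore expected in this assay, and no firm direction can be given. The expected step is a 1.2-fold lower number from compound 1 to compound 4 (0.06 log units; within the scatter). For compound 4 the estimated value is 40 ug/mL, with an expected range from 18 ug/mL to 90 ug/mL.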

Compound 4, half-maximal inhibitory concentration: 67 ug/mL
Beside the measured number, compound 4's estimate is 1.7-fold (0.22 log units) below it, and the stated range covers the measured number.
By their numbers in this assay, from the lowest: compounds 3, 1 and 4 (each within the scatter of the next); then compound 2.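

In this assay, among the compounds shown here, the new compound gives the first reading at this place, since every earlier step exchanged the methyl of compound 1 or the group standing in its stead, and chloro in place of hydrogen, ortho to a chloro group and meta to a large group, amounts to a 1.5-fold higher number from compound 1 to compound 4 (0.16 log units; within the scatter) on the shared core. Compound 1 and compound 4 therefore cannot be told apart in this read-out, so a single added chloro at this aromatic carbon shows neither a gain nor a loss, and no direction can be assigned to the change. No measurement that could speak to the reason for this result is available.

What the compounds shown leave open is whether other groups at this aromatic carbon, such as a methoxy group, an amine or a carboxylic acid, would also stay within the scatter of compound 1, since a single chloro says nothing about them. For the compounds shown here, it also remains open whether the added chloro would give a similar reading on the butoxy or 3-chloro-2-cyanophenoxy compounds, as it has been seen only with the methyl group in place.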